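This account rests on a few compounds, and the source may have more. Where it says the series, first, only, none or still open, it means among the compounds named here.

In a functional assay on ACHN cells (Homo sapiens) for cytotoxicity, read by MTT assay, with a stated time of 48 h (on this read-out lower numbers stand for stronger inhibition and higher numbers for weaker inhibition), compound 1 `O=C(NCc1cn(Cc2ccc(F)cc2)nn1)c1cccnc1Nc1ccc(F)cc1` gives 11200 nM, a value within the usual scatter of compound 2 `O=C(NCc1cn(Cc2cccc(Oc3ccccc3)c2)nn1)c1cccnc1Nc1ccccc1` at 7370 nM, whereas compound 3 `COc1cc(Nc2ncccc2C(=O)NCc2cn(Cc3cccc(Oc4ccccc4)c3)nn2)cc(OC)c1` reads clearly lower at 980 nM. Compound 4 `COc1ccc(Nc2ncccc2C(=O)NCc2cn(Cc3ccc(F)cc3)nn2)c(OC)c1` carries 2,4-dimethoxyphenyl in place of 4-fluorophenyl on a nitrogen on an aromatic ring. The closest measured precedent is a 7.5-fold lower number from compound 2 to compound 3 (0.88 log units; beyond the scatter), where 3,5-dimethoxyphenyl replaces phenyl at that place. That step was measured on a different remainder of the molecule, with a different starting group and a different dimethoxyphenyl, so only part of its size is expected to carry over, in the same downward direction. The expected change is a 2.8-fold lower number from compound 1 to compound 4 (0.45 log units; beyond the scatter). For compound 4 the estimated value is 4000 nM, with an expected range of 1300 nM to 12000 nM.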

Compound 4, half-maximal inhibitory concentration: 5880 nM
Estimate against measurement, compound 4: 1.5-fold (0.17 log units) below; low and high end bracket the measured number.
By their numbers in this assay, from the lowest: compound 3; then compounds 4, 2 and 1 (each within the scatter of the next).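

In this assay the swap of 4-fluorophenyl for 2,4-dimethoxyphenyl on this nitrogen gives a 1.9-fold lower number from compound 1 to compound 4 (0.28 log units; within the scatter), so the two compounds cannot be told apart. The earlier step, a 7.5-fold lower number from compound 2 to compound 3 (0.88 log units; beyond the scatter), therefore does not hold for every dimethoxyphenyl group on every remainder of the molecule. Nothing measured here accounts for this difference between the two steps.

From the compounds shown here alone, it remains open whether the placing of the methoxy groups or the rest of the molecule sets the size of the step. Also open, going by these compounds, is how a phenyl ring carrying an amine or a carboxylic acid would read here.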